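A few compounds are considered here, and "the series" means these few. Any claim that something is new, unique, unknown or untested is made for them only; others in the source may bear on it.

Notes on the series. The shared core is that of compound 1 `COc1ccc(/C(=C(/CCCl)c2ccccc2)c2ccccc2)cc1`. In a functional assay on MCF7 cells (Homo sapiens) for cytotoxicity, read by MTT assay, with a stated time of 72 h (a higher number here means a weaker inhibitor, a lower number a stronger inhibitor), compound 1 reports only the assay limit > 50000 nM (the limit of > 50000 nM in this assay, at which 1 of the 3 values shown sits), not a number. Compound 2 `COc1ccc(/C(=C(/CCN)c2ccccc2)c2ccccc2)cc1` gives 16900 nM in this assay. Compound 3 `COc1ccc(/C(=C(/CCNC(=O)NC2CCCCC2)c2ccccc2)c2ccccc2)cc1` gives 37200 nM, the higher of the two numbers measured, after a 2.2-fold higher number from compound 2 to compound 3 (0.34 log units; beyond the scatter). Compound 4 `COc1ccc(/C(=C(/CCNC(=O)N2CCCCC2)c2ccccc2)c2ccccc2)cc1` differs from compound 3 by piperidin-1-yl in place of cyclohexylamino on a carbonyl carbon. For the measured compounds named here, no measured step alters this part of the urea; the nearest, a 2.2-fold higher number from compound 2 to compound 3 (0.34 log units; beyond the scatter), introduced the whole cyclohexylcarbamoyl group, and an at least 1.3-fold lower number from compound 1 to compound 3 (0.12 log units; that floor lies within the scatter) starts from a limit and lies within the scatter. For compound 4 no step beyond the scatter is therefore expected, a 1.1-fold lower number from compound 3 to compound 4 (0.03 log units; within the scatter). Compound 4 is estimated at 35000 nM, with a range of 14000 nM to 90000 nM.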

Compound 4, half-maximal inhibitory concentration: > 50000 nM
Compound 4 was reported as a limit; the forecaster's own chance of this, stated with the estimate: 25%; middle value at least 1.4-fold (0.15 log units) from the limit.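

In this assay compound 4 stands at a limit, not a number: the limit of > 50000 nM in this assay, at which 2 of the 4 values shown sit.

Piperidin-1-yl in place of cyclohexylamino on the carbonyl carbon gives an at least 1.3-fold higher number from compound 3 to compound 4 (0.12 log units; that floor lies within the scatter), so this change at this position is not separated from the scatter, while an at least 2.9-fold higher number from compound 2 to compound 4 (0.47 log units; beyond the scatter) shows that this urea, like that of compound 3, gives a higher number than the free amine of compound 2. The step between compound 1 and compound 4 cannot be read, as both values are limits.

Open, going by these compounds, is whether a morpholin-4-yl or dimethylamino group on that carbonyl carbon, or a longer chain, would give a lower number than compound 2.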